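A few compounds are considered here, and "the series" means these few. Any claim that something is new, unique, unknown or untested is made for them only; others in the source may bear on it.

Measured so far:
compound 2 `NC1=NC2(CCOCC2)N(OCCCOc2ccc(Cl)cc2)C(N)=N1` — 33.6 nM
compound 1 `NC1=NC2(CCSCC2)N(OCCCOc2cccc(Cl)c2)C(N)=N1` — "not determined" (no result reported)

Going by the values given here, compound 2 carries the only number in an assay on isolated protein for inhibition of Dihydrofolate reductase (Homo sapiens), read by spectrophotometry, using NADPH, with stated times of 5 s and 6 min; on this read-out higher numbers stand for weaker inhibition and lower numbers for stronger inhibition; compound 1 gives no result in this assay, so there is nothing to set compound 2 against. Compound 3 `Cc1ccc(OCCCON2C(N)=NC(N)=NC23CCOCC3)cc1` differs from compound 2 by methyl in place of chloro on an aromatic carbon, para to a large group. No step between measured compounds is shown, so the size of this exchange is not known from the series. A small step is expected, a 1.6-fold higher number from compound 2 to compound 3 (0.21 log units; within the scatter), likely toward weaker inhibition and close to the scatter. Compound 3 is estimated at 55 nM in this assay, within 20 nM to 160 nM.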

Compound 3, half-maximal inhibitory concentration: 56.8 nM
Estimate against measurement, compound 3: 1.0-fold (0.01 log units) below; low and high end bracket the measured number.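

In this assay, going by these compounds alone, the one step at this position reads a 1.7-fold higher number from compound 2 to compound 3 (0.23 log units; within the scatter) and so does not separate 4-chlorophenyl from 4-methylphenyl. On this pair, methyl can stand in for chloro on the aromatic carbon para to a large group with no difference beyond the scatter. Nothing available here bears on the reason for this reading.

On these data alone, whether an amine, a carboxylic acid or a methoxy group at this position would read the same stays open. So does the outcome of a longer chain leading to the aromatic ring.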